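A few compounds are considered here, and "the series" means these few. Any claim that something is new, unique, unknown or untested is made for them only; others in the source may bear on it.

Working notes on the series, read in a functional assay on U-87MG ATCC cells for antiproliferative activity against U-87 MG (Homo sapiens), read by MTT assay, with a stated time of 48 h; on this read-out lower numbers stand for stronger inhibition and higher numbers for weaker inhibition. Of the compounds shown here, three have numbers so far. Compound 1 `Cc1nc(-c2ccc(Cl)cc2)sc1C(=O)CSc1nc(-c2ccccc2)c(C#N)c(=O)[nH]1` gives 27600 nM and compound 2 `COc1ccc(-c2nc(SCC(=O)c3sc(-c4ccccc4)nc3C)[nH]c(=O)c2C#N)cc1` gives 48400 nM, two values within the scatter of each other. Compound 3 `COc1ccc(-c2nc(C)c(C(=O)CSc3nc(N)c(C#N)c(-c4ccccc4)n3)s2)cc1` gives 8540 nM. The gap between compound 2 and compound 3 lies beyond the scatter, with compound 2 on the weaker side, so compound 2 stands in the weak part of this small set, level with compound 1.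

Compound 4 `COc1ccc(-c2nc(C)c(C(=O)CSc3nc(-c4ccc(OC)cc4)c(C#N)c(=O)[nH]3)s2)cc1` has no number yet. Its difference from compound 2 is methoxy in place of hydrogen on an aromatic carbon, phenyl to 4-methoxyphenyl. For the measured compounds named here, no pair of measured compounds differs in one place only, so the set offers no direct precedent for this change. The expectation therefore starts from compound 2 at 48400 nM, and no shift beyond the scatter is expected in this assay. The estimated step is a 1.2-fold lower number from compound 2 to compound 4 (0.06 log units; within the scatter), a small move towards stronger inhibition that stays within the scatter. Compound 4 is estimated at 42000 nM, with an expected range of 17000 nM to 100000 nM.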

Compound 4, half-maximal inhibitory concentration: 25300 nM
The estimate for compound 4 lay 1.7-fold (0.22 log units) above the measured number; the range from low to high includes it.
By their numbers in this assay, from the lowest: compound 3; then compounds 4, 1 and 2 (each within the scatter of the next).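

In this assay, for the compounds shown here, the change from phenyl to 4-methoxyphenyl gives a 1.9-fold lower number from compound 2 to compound 4 (0.28 log units; within the scatter), the first step that isolates a single place. At this aromatic carbon, para to a large group, replacing hydrogen with methoxy therefore produces no change that can be separated from the usual scatter, though this rests on a single pair and sets no trend. Nothing measured alongside this step speaks to what lies behind the result.

Going by these compounds, it remains open whether a different group on the same carbon, such as an amine, a carboxylic acid or a longer alkoxy chain, would give a step beyond the scatter. It is also open whether methoxy in place of hydrogen would give a similarly small step on the core of compound 3, since the compounds shown include no pair that tests this change there.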